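A few compounds are considered here, and "the series" means these few. Any claim that something is new, unique, unknown or untested is made for them only; others in the source may bear on it.

Of the compounds shown here, two have been measured in a functional assay on PC-3 cells (Homo sapiens) for antiproliferative activity, read by MTT assay, with a stated time of 48 h; on this read-out lower numbers stand for stronger inhibition and higher numbers for weaker inhibition. Compound 1 `O=C(Nc1cc(Sc2ncn[nH]2)c(O)c2ccccc12)c1ccc([N+](=O)[O-])cc1` gives 53500 nM in this assay, and compound 2 `O=C(Nc1cc(Sc2ncnc3nc[nH]c23)c(O)c2ccccc12)c1ccc(Cl)cc1` gives 66400 nM in this assay. Compound 2 carries the higher of the two numbers, but the two values lie within the scatter of one another, so no order between them can be read from the data. The unmeasured compound 3 `O=C(Nc1cc(Sc2ncnc3nc[nH]c23)c(O)c2ccccc12)c1ccc([N+](=O)[O-])cc1` is derived from compound 2 by a single change, (nitro in place of chloro on an aromatic carbon), that is, nitro in place of chloro on an aromatic carbon. Compound 1 already carries a nitro group on a different core and its value sits close to that of compound 2, so no step beyond the scatter is expected from compound 2 to compound 3; the expected step is a 1.1-fold lower number from compound 2 to compound 3 (0.06 log units; within the scatter). Compound 3 is accordingly estimated at 58000 nM in this assay, within a range of 25000 nM to 130000 nM.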

Compound 3, half-maximal inhibitory concentration: > 100000 nM
Compound 3: only a limit was reported (the forecaster's own chance of this, stated with the estimate: 15%); middle value at least 1.7-fold (0.23 log units) from the limit.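

In this assay compound 3 is reported only as a limit: the limit of > 100000 nM in this assay, at which 1 of the 3 values shown sits. Among the compounds shown here, these compounds now allow the first comparisons of single changes: nitro in place of chloro on the aromatic carbon gives an at least 1.5-fold higher number from compound 2 to compound 3 (0.17 log units; that floor lies within the scatter), and changing the group on the sulfur gives an at least 1.8-fold higher number from compound 1 to compound 3 (0.27 log units; that floor lies within the scatter). Both steps are floors that lie within the scatter, so neither change is shown to raise the number, but neither points to a lower one, and the 4-nitrophenyl group gives no sign of stronger inhibition with either group on the sulfur.

From the compounds shown here alone, how far compound 3 really lies from compound 1 and compound 2 stays open. So does whether an amine or a methoxy group in place of the chloro would give a lower number on this core.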